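A Methyl Group That Carries the Whole Inhibitory Effect

The compounds below may be only part of what the source reports. "The series", "measured", "known", "first", "only" and "open" are said of these compounds alone.

Of the compounds shown here, three have been tested so far in a functional assay on CHO cells for antagonist activity at metabotropic glutamate receptor 5 (Rattus norvegicus), read by FLIPR and calcium flux; on this read-out higher numbers stand for weaker inhibition and lower numbers for stronger inhibition. Compound 1 `Cc1ccc2cnc(-c3cccc(C#N)c3)nc2n1` bears a nitrile on its pendant ring and a methyl on the shared core; in this assay compound 1 gives 240 nM. Compound 2 `Cc1ccc2cnc(-c3cc(Cl)cc(Cl)c3)nc2n1` carries two chlorines on the pendant ring instead, and in this assay compound 2 gives 0.72 nM. How the pendant parts of compound 1 and compound 2 differ is not broken down here.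

Compound 3 `N#Cc1cccc(-c2ncc3cccnc3n2)c1` is compound 1 with the methyl removed, the change being (hydrogen in place of methyl on an aromatic carbon). The value recorded for compound 3 in this assay is a limit of the assay rather than a number: > 26100 nM. The step of an at least 100-fold higher number from compound 1 to compound 3 (2.03 log units; beyond the scatter) therefore rests on (the limit of > 26100 nM in this assay, at which 1 of the 3 values shown sits), so only its lower bound is known.

Compound 4 `Clc1cc(Cl)cc(-c2ncc3cccnc3n2)c1`, not yet measured, stands to compound 2 exactly as compound 3 stands to compound 1; the change is hydrogen in place of methyl on an aromatic carbon, the same change at the same place. Since the removal of the methyl cost compound 1 so much in the step of an at least 100-fold higher number from compound 1 to compound 3 (2.03 log units; beyond the scatter), a similar loss is expected for compound 4 from compound 2, so that the expected step is a 280-fold higher number from compound 2 to compound 4 (2.44 log units; beyond the scatter). Compound 4 is accordingly estimated to give 200 nM in this assay, most likely between 30 nM and 3000 nM.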

Compound 4, half-maximal inhibitory concentration: 228 nM
Compound 4: middle estimate off by 1.1-fold (0.06 log units), on the low side; low and high end bracket the measured number.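

In this assay, putting hydrogen in place of the methyl gives a 320-fold higher number from compound 2 to compound 4 (2.50 log units; beyond the scatter) and so repeats on the compound with two chlorines the large loss of inhibition already seen on the compound with a nitrile. This supports carrying the change from one pendant ring to the other in this series, but it rests on just two matched pairs, so it sets no rule for other pendant rings, and it does not show that the two losses are equal in size: the same change on two cores in this assay, an at least 100-fold higher number (2.03 log units; beyond the scatter) from compound 1 to compound 3 and a 320-fold higher number (2.50 log units; beyond the scatter) from compound 2 to compound 4; the limit leaves it open whether they differ. Going by these compounds, compound 3 stands at > 26100 nM as a limit of the assay and not a number, so the true size of the first step remains unknown and only its lower bound can be used: the limit of > 26100 nM in this assay, at which 1 of the 4 values shown sits.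

The compounds shown have only a methyl or a hydrogen at this place on the shared core, so it stays open whether an ethyl group, a longer chain, a methoxy group or an amine there would keep the inhibition that the methyl gives. On these data alone, it also stays open whether the same large loss would appear with a pendant ring carrying a single chlorine, a carboxylic acid or an amide.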